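Removing a methoxy from the benzyl end of compound 1

The source may hold more compounds than are shown below. What is called first, only, known or untested is meant among the compounds shown, and "the series" means these compounds.

compound 1 `COc1ccc(Cc2nnc(NC(=O)/C(C#N)=C/c3ccccc3OS(=O)(=O)c3ccc(OC)cc3)s2)cc1` gives 840 nM
compound 2 `COc1ccc(Cc2nnc(NC(=O)/C(C#N)=C/c3ccccc3OS(=O)(=O)c3ccc([N+](=O)[O-])cc3)s2)cc1` gives 3670 nM
compound 3 `COc1ccc(Cc2nnc(NC(=O)/C(C#N)=C/c3ccccc3OS(=O)(=O)c3ccc(Cl)cc3)s2)cc1` gives 4020 nM

In a functional assay on RS4-11 cells (Homo sapiens) for inhibition, read by CCK-8 assay, with a stated time of 48 h (on this read-out lower numbers stand for stronger inhibition and higher numbers for weaker inhibition), compound 1 has the lowest number of the three, and both steps away from it lie beyond the scatter: a 4.4-fold higher number from compound 1 to compound 2 (0.64 log units; beyond the scatter), and a 4.8-fold higher number from compound 1 to compound 3 (0.68 log units; beyond the scatter). Compound 2 and compound 3 do not separate, with a 1.1-fold higher number from compound 2 to compound 3 (0.04 log units; within the scatter).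

Compound 4 `COc1ccc(S(=O)(=O)Oc2ccccc2/C=C(\C#N)C(=O)Nc2nnc(Cc3ccccc3)s2)cc1` has not yet been measured. Its difference from compound 1 is hydrogen in place of methoxy on an aromatic carbon, which also reads as 4-methoxybenzyl to benzyl.

Within the data shown here, no measured step tests this change directly. Compound 2 and compound 3 keep the 4-methoxybenzyl group and replace the other methoxy of compound 1, so they offer only indirect guidance. Both of those replacements gave modest steps toward higher numbers, and no replacement of a methoxy in this small set gave a lower number. A modest step toward a higher number is therefore expected in this assay, probably no larger than those two, and a result within the scatter of compound 1 would not be surprising. For compound 4 the estimated value is 1500 nM, with an expected range of 600 nM to 4000 nM. The expected step is a 1.8-fold higher number from compound 1 to compound 4 (0.25 log units; within the scatter).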

Compound 4, half-maximal inhibitory concentration: 1060 nM
Estimate against measurement, compound 4: 1.4-fold (0.15 log units) above, within the range that was stated.
By their numbers in this assay, from the lowest: compounds 1 and 4 (each within the scatter of the next); then compounds 2 and 3 (each within the scatter of the next).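

In this assay, the change from 4-methoxybenzyl to benzyl gives a 1.3-fold higher number from compound 1 to compound 4 (0.10 log units; within the scatter), so the methoxy at this end of compound 1 can be replaced by hydrogen with the number staying within the scatter. The earlier compounds shown here covered only the other methoxy, where nitro gives a 4.4-fold higher number from compound 1 to compound 2 (0.64 log units; beyond the scatter) and chloro gives a 4.8-fold higher number from compound 1 to compound 3 (0.68 log units; beyond the scatter), both beyond the scatter; the two methoxy groups of compound 1 therefore do not behave alike under replacement in this small set, and a number at the level of compound 1 does not depend on the methoxy of the 4-methoxybenzyl group. The data shown offer no measurement that would explain either outcome.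

On these data alone, with only methoxy and hydrogen tested at this position, it remains open whether the tolerance extends to other groups there, such as an amine, a carboxylic acid or a longer alkoxy chain. As far as these compounds go, it is also open whether the benzyl end of compound 4 would give the same result when paired with nitro or chloro at the other end of the molecule.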